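Bromophenyl Sulfonamide Weighed Against Three Limit Values

The source may hold more compounds than are shown below. What is called first, only, known or untested is meant among the compounds shown, and "the series" means these compounds.

Compound 3 `CC1CCN(C2CCN(S(=O)(=O)c3cnc(Cl)s3)CC2)CC1` is the measured starting point of this step. In an ADME assay on HCT-116 cells (Homo sapiens) for cytotoxicity, read by CellTiter-Glo, with a stated time of 72 h (a higher number here means a weaker inhibitor, a lower number a stronger inhibitor), compound 3 gives > 10000 nM, which is a limit of the assay and not a number. Compound 1 `CC1CCN(C2CCN(S(=O)(=O)c3sc(Cl)nc3C3CC3)CC2)CC1` gives > 10000 nM in this assay, again a limit rather than a number. Compound 2 `Cc1cc(C)c(S(=O)(=O)N2CCC(N3CCC(CCO)CC3)CC2)c(C)c1` gives > 5000 nM in this assay, also a limit. Compound 3 thus stands where everything else in this set stands: of the values shown, two sit at the limit of > 10000 nM in this assay, at which 2 of the 3 values shown sit, and one at the limit of > 5000 nM in this assay, at which 1 of the 3 values shown sits, and none is a real number.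

For the measured compounds named here, the only step between measured compounds is a step that the two limits leave unreadable from compound 1 to compound 3; with both ends at limits, its size cannot be read. Compound 4 `CC1CCN(C2CCN(S(=O)(=O)c3ccccc3Br)CC2)CC1` is the compound not yet measured. It differs from compound 3 by 2-bromophenyl in place of 2-chloro-1,3-thiazol-5-yl on a sulfonyl sulfur. Going by the values given here, no measured step bears directly on this change, and the one step that exists is unreadable, so the data point to no direction for it. Since every value shown is a limit, the estimated step that the limit leaves unreadable from compound 3 to compound 4 is expected to leave the result at a limit as well. Compound 4 is expected to give about 15000 nM in this assay, within an estimated range from 5000 nM to 50000 nM.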

Compound 4, half-maximal inhibitory concentration: > 5000 nM
Compound 4 was reported as a limit; the forecaster's own chance of this, stated with the estimate: 85%; the middle value does not contradict the limit.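

In this assay compound 4 gives > 5000 nM, a limit and not a number. Compound 3 gives > 10000 nM, also a limit, so no step can be read between compound 3 and compound 4. The compounds shown leave open whether 2-bromophenyl in place of 2-chloro-1,3-thiazol-5-yl on a sulfonyl sulfur changes the read-out at all.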